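The source may report more compounds than this note shows. Statements on the series, on what has been measured and on what is new or still open speak of the compounds shown alone.

Measured compounds:
compound 1: `O=C1c2ccccc2N(Cc2ccccc2)S(=O)(=O)N1Cc1ccc(Cl)cc1`
compound 2: `O=C1c2ccccc2N(Cc2ccc(Cl)c(Cl)c2)S(=O)(=O)N1Cc1ccccc1`

In a functional assay on HEL cells (Homo sapiens) for inhibition (a higher number here means that more compound is tolerated, a lower number that less compound is tolerated), compound 1 gives 121000 nM. For compound 2 the assay reports only a limit, > 200000 nM, and not a number. Compound 2 therefore sits at the edge of what the measured values show, as one of the two values recorded at the limit of > 200000 nM in this assay, at which 1 of the 2 values shown sits.

Compound 3, `O=C1c2ccccc2N(Cc2cccc(Cl)c2)S(=O)(=O)N1Cc1ccccc1`, is to be measured in this assay. It differs from compound 2 in one place: hydrogen in place of chloro on an aromatic carbon. Among the compounds with values here, no measured pair of this kind is available, so the size of the change in this assay cannot be read from a neighbouring step; the expectation is a change no larger than the usual scatter, with the direction left open. Compound 3 is expected to give about 170000 nM, within a range from 80000 nM to 300000 nM. The expected step is an at least 1.1-fold lower number from compound 2 to compound 3 (0.07 log units; that floor lies within the scatter), and a second limit-only result is a real possibility.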

Compound 3, half-maximal cytotoxic concentration: > 200000 nM
Compound 3 ended at the assay's limit; the forecaster's own chance of this, stated with the estimate: 45%; at least 1.1-fold (0.07 log units) between middle value and limit.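

Compound 2 and compound 3 both stand at a limit of this assay, not at a number, so no step between compound 2 and compound 3 can be read: the limit of > 200000 nM in this assay, at which 2 of the 3 values shown sit.

The compounds shown leave open whether 3,4-dichlorobenzyl and 3-chlorobenzyl differ at all in this assay.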